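The source may hold more compounds than are shown below. What is called first, only, known or untested is meant among the compounds shown, and "the series" means these compounds.

Among the compounds with values here, compound 1 `COc1ccc(F)c(-c2ccc3c(NC(=O)c4ccc(N(C)CCN(C)C)cc4)n[nH]c3c2)c1F` is the only compound of this set with a numerical result: in a functional assay on KG-1 cells (Homo sapiens) for antiproliferative activity, read by CCK-8 assay, with a stated time of 72 h (on this read-out lower numbers stand for stronger inhibition and higher numbers for weaker inhibition), compound 1 gives 333 nM. Compound 2 `CCN1CCN(c2ccc(C(=O)Nc3n[nH]c4cc(-c5cccc(OC)c5F)cc(F)c34)cc2)CC1` is the other measured compound, and in this assay compound 2 reaches only a limit, > 1000 nM, so no number is available for it. The comparison of the two values therefore rests on (the limit of > 1000 nM in this assay, at which 1 of the 2 values shown sits), which leaves the gap between compound 1 and compound 2 undefined beyond the fact that compound 1 sits inside the measured range and compound 2 does not.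

Compound 3 `COc1ccc(F)c(-c2ccc3c(NC(=O)c4ccc(N5CCN(C)CC5)cc4)n[nH]c3c2)c1F` has not yet been measured. Compared with compound 1, the change in compound 3 is 4-methylpiperazin-1-yl in place of (2-(dimethylamino)ethyl)(methyl)amino on an aromatic carbon, a swap of one group for another of the same atom count and the same donor and acceptor count, with the entering group closed into a ring. Within the data shown here, no measured pair traces this change in the present data. With compound 2 carrying a related ring group and only a limit, the step from compound 1 to compound 3 is expected to be a modest weakening, a 1.8-fold higher number from compound 1 to compound 3 (0.26 log units; within the scatter), and compound 3 is estimated at 600 nM in this assay, within a range of 250 nM to 1500 nM.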

Compound 3, half-maximal inhibitory concentration: 41.5 nM
For compound 3 the middle estimate is 14-fold (1.16 log units) above the measured one; measured number below the stated range.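

Within the data shown here, this is the first pair in the set that differs in one place, and it shows that this position, on an aromatic carbon para to a large group, responds clearly in this assay: 4-methylpiperazin-1-yl in place of (2-(dimethylamino)ethyl)(methyl)amino gives an 8.0-fold lower number from compound 1 to compound 3 (0.90 log units; beyond the scatter). The two groups have the same heavy-atom, carbon, nitrogen, hydrogen-bond donor and hydrogen-bond acceptor counts, and neither carries a net charge, so among the listed features they differ in the six-membered non-aromatic ring of the entering group. Nothing measured here accounts for the size of this step.

This single pair cannot separate the closing of the ring from the placement of the nitrogen atoms, and a piperidine, a morpholine or a 4-ethylpiperazin-1-yl group at the same position would bear on that question. Compound 2 stands at > 1000 nM in this assay, which is a limit and not a number, and as it differs from the other compounds in more than one place, steps involving it cannot be read.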